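The source may report more compounds than this note shows. Statements on the series, on what has been measured and on what is new or still open speak of the compounds shown alone.

In a functional assay on SW480 cells (Homo sapiens) for antiproliferative activity, read by sulforhodamine B assay, with a stated time of 48 h (a lower number here means a stronger inhibitor, a higher number a weaker inhibitor), compound 3 `COc1cc(OC)c(/C=C/C(=O)C(=Cc2ccc(O)c(F)c2)C(=O)/C=C/c2c(OC)cc(OC)cc2OC)c(OC)c1` gives 1950 nM and compound 2 `COc1cc(OC)c(/C=C/C(=O)C(=Cc2ccc(O)c(OC)c2)C(=O)/C=C/c2c(OC)cc(OC)cc2OC)c(OC)c1` gives 1490 nM. These two sit together, with a 1.3-fold higher number from compound 2 to compound 3 (0.12 log units; within the scatter). Compound 1 `COc1cc(C=C(C(=O)/C=C/c2cccc(OC)c2OC)C(=O)/C=C/c2cccc(OC)c2OC)cc(OC)c1O` gives 420 nM, a number clearly lower than that of compound 3.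

Compound 4 `COc1cc(OC)c(/C=C/C(=O)C(=Cc2cc(OC)c(O)c(OC)c2)C(=O)/C=C/c2c(OC)cc(OC)cc2OC)c(OC)c1` departs from compound 3 in one group: 4-hydroxy-3,5-dimethoxyphenyl in place of 3-fluoro-4-hydroxyphenyl on a double-bonded chain carbon bound to a double-bonded chain carbon. The rest of the structure stays the same.

For the measured compounds named here, only one measured step bears directly on this change. It is a 1.3-fold higher number from compound 2 to compound 3 (0.12 log units; within the scatter), fluoro in place of methoxy on an aromatic carbon of the same aryl group, and it shows this group tolerating exchange without a change beyond the scatter. Going by the values given here, that is a single step, and no measured compound pairs the entering group with the other aryl groups of compound 3. Compound 1, at 420 nM, also carries the 4-hydroxy-3,5-dimethoxyphenyl group but differs in its other aryl groups, so it offers only a slight pull toward a lower number.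

In this assay the expected step is a 1.5-fold lower number from compound 3 to compound 4 (0.18 log units; within the scatter), so none beyond the scatter is anticipated, with a slight lean downward. The estimate for compound 4 is 1300 nM, with an expected range of 550 nM to 2800 nM.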

Compound 4, half-maximal inhibitory concentration: 980 nM
Estimate against measurement, compound 4: 1.3-fold (0.12 log units) above; the range from low to high includes it.
By their numbers in this assay, from the lowest: compound 1; then compounds 4, 2 and 3 (each within the scatter of the next).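

In this assay, the aryl group on the double-bonded chain carbon bound to a double-bonded chain carbon can now be compared across three variants: replacing 3-fluoro-4-hydroxyphenyl with 4-hydroxy-3,5-dimethoxyphenyl gives a 2.0-fold lower number from compound 3 to compound 4 (0.30 log units; within the scatter) and adding a methoxy in place of hydrogen gives a 1.5-fold lower number from compound 2 to compound 4 (0.18 log units; within the scatter) with the other aryl groups held constant. Together with the earlier step, these results show that the 4-hydroxy-3,5-dimethoxyphenyl group, earlier seen only in compound 1, is tolerated alongside the other aryl groups of compound 3, and that neither change moves the number beyond the scatter. No measured evidence accounts for this flat response at the position.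

Going by these compounds, all of the aryl variants at this position keep the hydroxy group, so the outcome with an amine or a carboxylic acid in its place remains open. For the compounds shown here, the contribution of the other aryl groups also remains open, since compound 1 with 420 nM stands alone in carrying different ones and no single-change step links it to the other compounds.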